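Working notes: methoxy in place of chloro

This account rests on a few compounds, and the source may have more. Where it says the series, first, only, none or still open, it means among the compounds named here.

Compound 1 `N#C/C(=C/c1ccc2ccccc2c1)C(=O)c1ccc[nH]1`: < 10000 nM (a limit)
Compound 2 `N#C/C(=C/c1ccc(Cl)cc1)C(=O)c1ccc[nH]1`: 63000 nM

Within the data shown here, in a functional assay on BE(2)-C cells (Homo sapiens) for cytotoxicity, read by MTT assay, with a stated time of 72 h (a lower number here means a stronger inhibitor of growth, a higher number a weaker inhibitor of growth), compound 2 gives 63000 nM, the only true number so far. Compound 1 reads < 10000 nM, which is a limit of the assay and not a number.

Compound 3 `COc1ccc(/C=C(/C#N)C(=O)c2ccc[nH]2)cc1` has methoxy in place of chloro on an aromatic carbon, para to a large group (methoxy in place of chloro on an aromatic carbon). Among the measured compounds shown here, no measured step covers this change.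

The step expected in this assay is a 1.6-fold lower number from compound 2 to compound 3 (0.20 log units; within the scatter), none beyond the scatter. The estimate for compound 3 is 40000 nM, with an expected range of 12000 nM to 100000 nM.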

Compound 3, concentration for 50% growth inhibition: < 10000 nM
Compound 3 was reported as a limit; the forecaster's own chance of this, stated with the estimate: 15%; at least 4.0-fold (0.60 log units) between middle value and limit.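

In this assay, among these compounds, an at least 6.3-fold lower number from compound 2 to compound 3 (0.79 log units; beyond the scatter) comes with methoxy in place of chloro on an aromatic carbon, para to a large group, the first step that can be read. Compound 3 at < 10000 nM is a limit and not a number. The full size of the step therefore stays unread, and no order can be read among the compounds at the limit: the limit of < 10000 nM in this assay, at which 2 of the 3 values shown sit.

Open, as far as these compounds go, is how a hydroxy group or an amine would read at this position. Also open, from the compounds shown here alone, is whether a longer chain on the oxygen would move the number further.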